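This account rests on a few compounds, and the source may have more. Where it says the series, first, only, none or still open, it means among the compounds named here.

Series notes. The parent is compound 1 `c1ccc(-c2noc(-c3cc4ccccc4[nH]3)n2)cc1`; in a functional assay on COLO 320 cells (Homo sapiens) for antiproliferative activity, read by WST assay, with a stated time of 72 h (on this read-out higher numbers stand for weaker inhibition and lower numbers for stronger inhibition), compound 1 gives 12000 nM. Compound 2 `COc1ccc2[nH]c(-c3nc(-c4ccccc4)no3)cc2c1` carries methoxy in place of hydrogen on an aromatic carbon and in this assay compound 2 gives 18700 nM, a step of a 1.6-fold higher number from compound 1 to compound 2 (0.19 log units; within the scatter). Compound 3 `Clc1ccc(-c2noc(-c3cc4ccccc4[nH]3)n2)cc1` differs from compound 1 by chloro in place of hydrogen on an aromatic carbon; in this assay compound 3 gives 13900 nM, a step of a 1.2-fold higher number from compound 1 to compound 3 (0.06 log units; within the scatter). The three measured values sit close together, and none of the steps between them is beyond the scatter.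

Compound 4 `COc1ccc2[nH]c(-c3nc(-c4ccc(Cl)cc4)no3)cc2c1` remains to be measured. It differs from compound 3 by methoxy in place of hydrogen on an aromatic carbon, the same change, at the same place, that takes compound 1 to compound 2; the two cores differ by the chloro group told above. Among the compounds with values here, only one instance of the change has been measured, so the expectation for compound 4 rests on that single step together with compound 3 at 13900 nM. An estimated step of a 1.5-fold higher number from compound 3 to compound 4 (0.18 log units; within the scatter) is expected, of about the size seen from compound 1 to compound 2, with the two values again likely to lie within the scatter of each other. Compound 4 is therefore estimated at 21000 nM, with a plausible range from 11000 nM to 40000 nM.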

Compound 4, half-maximal inhibitory concentration: 12800 nM
For compound 4 the middle estimate is 1.6-fold (0.22 log units) above the measured one; the measured number falls inside the stated range.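

In this assay, methoxy in place of hydrogen on an aromatic carbon gives a 1.1-fold lower number from compound 3 to compound 4 (0.04 log units; within the scatter), and chloro in place of hydrogen on an aromatic carbon gives a 1.5-fold lower number from compound 2 to compound 4 (0.16 log units; within the scatter). The methoxy change reads alike on both cores, with no gap beyond the scatter: the same change on two cores in this assay, a 1.6-fold higher number (0.19 log units; within the scatter) from compound 1 to compound 2 and a 1.1-fold lower number (0.04 log units; within the scatter) from compound 3 to compound 4, 1.7-fold (0.23 log units) apart, within the scatter of two such steps. The chloro change reads alike as well, which shows that neither change depends detectably on the core across these four compounds but does not show that either group has a real effect to carry over, as every step lies within the scatter: the same change on two cores in this assay, a 1.2-fold higher number (0.06 log units; within the scatter) from compound 1 to compound 3 and a 1.5-fold lower number (0.16 log units; within the scatter) from compound 2 to compound 4, 1.7-fold (0.23 log units) apart, within the scatter of two such steps.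

As far as these compounds go, whether any substituent on these positions can move the number beyond the scatter remains open, as does whether this flat picture holds outside compounds 1 to 4. An amine or a carboxylic acid in place of the methoxy, or a longer chain such as butoxy, would put that question to the shared core.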